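The source may report more compounds than this note shows. Statements on the series, on what has been measured and on what is new or still open speak of the compounds shown alone.

Measured in a functional assay on BT-474 cells (Homo sapiens) for cytotoxicity, read by trypan blue exclusion, with a stated time of 96 h; on this read-out lower numbers stand for stronger inhibition of growth and higher numbers for weaker inhibition of growth:
- compound 1 `COc1ccc(NS(=O)(=O)/C=C/c2c(OC)cc(OC)cc2OC)cc1`: 250 nM
- compound 2 `COc1cc(OC)c(/C=C/S(=O)(=O)Nc2ccc(OC)c(O)c2)c(OC)c1`: 25 nM

Of these two, compound 2 holds the lower number, at 25 nM. Compound 3 `COc1cc(OC)c(/C=C/S(=O)(=O)Nc2ccc(OC)c(N)c2)c(OC)c1` departs from it in one place: amino in place of hydroxy on an aromatic carbon. The new amino group sits on an aromatic carbon, ortho to a methoxy group and meta to a large group.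

Among the compounds with values here, only one measured step bears on this change. It is a 10-fold lower number from compound 1 to compound 2 (1.00 log units; beyond the scatter), where hydroxy replaced hydrogen at that carbon. Within the data shown here, no measurement yet compares amino with hydroxy. Going by these compounds, that step shows that this place can move the number, but it began from hydrogen, so nothing of its size is expected here, and the direction remains open. The expected result is a 1.3-fold lower number from compound 2 to compound 3 (0.10 log units; within the scatter). Compound 3 is estimated at 20 nM, with an expected range of 6 nM to 70 nM.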

Compound 3, concentration for 50% growth inhibition: 10 nM
Estimate against measurement, compound 3: 2.0-fold (0.30 log units) above; the range from low to high includes it.
By their numbers in this assay, from the lowest: compound 3; then compound 2; then compound 1.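

In this assay, the carbon that took hydroxy also accepts amino, and the exchange gives a 2.5-fold lower number from compound 2 to compound 3 (0.40 log units; beyond the scatter) rather than merely keeping the earlier gain. Measured from hydrogen, amino gives a 25-fold lower number from compound 1 to compound 3 (1.40 log units; beyond the scatter) and so goes further than hydroxy did, which shows that the number at this carbon depends on which group stands there and not only on hydrogen being replaced. Nothing available here accounts for amino giving the lower number.

Going by these compounds, it remains open whether a methylamino or acetamido group at this carbon would keep the number reached with amino, or whether fluorine or hydroxymethyl would fit the same trend. The compounds shown also leave open whether amino would give the same result if the 4-methoxy group beside it gave way to ethoxy or hydrogen.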